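A few compounds are considered here, and "the series" means these few. Any claim that something is new, unique, unknown or untested is made for them only; others in the source may bear on it.

In a functional assay on MCF7 cells (Homo sapiens) for antiproliferative activity, read by MTT assay, with a stated time of 48 h (a lower number here means a stronger inhibitor, a higher number a weaker inhibitor), compound 1 (`COc1ccc(-c2nc3cccc(-c4cc(OC)c(OC)c(OC)c4)c3o2)cc1OC`) gives > 25000 nM as a limit of the assay, not a number. Compound 2 (`COc1cc(-c2cccc3nc(-c4ccc(F)cc4)oc23)cc(OC)c1OC`) gives > 25000 nM as a limit too, so it has no readable place in the series. For the measured compounds named here, the series so far stands at the limit of > 25000 nM in this assay, at which 2 of the 2 values shown sit, without exception. Going by the values given here, the only measured step is a step that the two limits leave unreadable from compound 1 to compound 2 and it supplies no size to carry forward. Compound 3 (`COc1cc(-c2cccc3nc(-c4cccc(Br)c4)oc23)cc(OC)c1OC`) has 3-bromophenyl in place of 4-fluorophenyl on an aromatic carbon of the five-membered aromatic ring with 1 nitrogen and 1 oxygen (3-bromophenyl in place of 4-fluorophenyl on an aromatic carbon). With no readable step behind this change, no shift beyond the scatter and no direction is expected in this assay for it. The expected step of a number no higher from compound 2 to compound 3 (the limit leaves the size open) is therefore only nominal. Compound 3 is estimated at 25000 nM with an expected range from 8000 nM to 50000 nM and is likely to be reported as a limit.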

Compound 3, half-maximal inhibitory concentration: > 25000 nM
Compound 3: a limit, no number; the forecaster's own chance of this, stated with the estimate: 70%; the middle value lies on the limit itself.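

In this assay compound 3 gives > 25000 nM, a limit of the assay and not a number. No new step can be read between compound 3 and compound 1 or compound 2. The compounds shown leave open whether any group at this place on the shared core gives a readable value in this assay.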